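Capping a Hydroxy Group in a Growth-Inhibiting Urea

The source may report more compounds than this note shows. Statements on the series, on what has been measured and on what is new or still open speak of the compounds shown alone.

In a functional assay on SNB-19 cells (Homo sapiens) for antiproliferative activity, read by sulforhodamine B assay, with a stated time of 48 h (a lower number here means a stronger inhibitor of growth, a higher number a weaker inhibitor of growth), compound 1 `O=C(NCCCNc1cc(-c2cn(-c3ccccc3)nc2-c2cccc(O)c2)ccn1)Nc1ccc(F)cc1` gives 9750 nM
In this assay compound 2 `O=C(NCCCNc1cc(-c2cn(-c3ccccc3)nc2-c2cccc(O)c2)ccn1)Nc1cccc(C(F)(F)F)c1` gives 8970 nM

For the measured compounds named here, these two numbers lie within the usual scatter of each other, so compound 1 stands level with the only other compound measured. Going by the values given here, the one measured step, a 1.1-fold lower number from compound 1 to compound 2 (0.04 log units; within the scatter), places 3-(trifluoromethyl)phenyl in place of 4-fluorophenyl on an amide-type nitrogen.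

Compound 3 `COc1cccc(-c2nn(-c3ccccc3)cc2-c2ccnc(NCCCNC(=O)Nc3ccc(F)cc3)c2)c1` changes a different place: methyl in place of hydrogen on an oxygen on an aromatic ring, so that 3-hydroxyphenyl becomes 3-methoxyphenyl. Among the compounds with values here, no measured step touches this group, and the data therefore give no direction for the change. The step to compound 2 is only an indirect guide, showing one change elsewhere that left this assay within the scatter. With so little evidence, no shift beyond the scatter is expected, and the expected step is a 1.1-fold lower number from compound 1 to compound 3 (0.03 log units; within the scatter) in size. For compound 3 the estimated value is 9000 nM, with an expected range from 3500 nM to 23000 nM as a deliberately wide allowance.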

Compound 3, concentration for total growth inhibition: > 37000 nM
Compound 3 was reported as a limit; the forecaster's own chance of this, stated with the estimate: 10%; middle value at least 4.1-fold (0.61 log units) away from the limit.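

Adding one methyl to the oxygen of the 3-hydroxyphenyl group is the first change here to move the number beyond the scatter: an at least 3.7-fold higher number from compound 1 to compound 3 (0.57 log units; beyond the scatter), and in this assay a higher number means weaker inhibition of growth. For the compounds shown here, this position therefore responds to a small change, whereas the only earlier step, on the amide-type nitrogen, gave a 1.1-fold lower number from compound 1 to compound 2 (0.04 log units; within the scatter). The true size of the new step remains unknown, since compound 3 is recorded only as a limit and not as a number: the limit of > 37000 nM in this assay, at which 1 of the 3 values shown sits.

The compounds shown cannot separate the loss of the hydroxy hydrogen from the arrival of the methyl, so it remains open which of the two matters, and an amine or a fluorine in place of the hydroxy group, or a longer ethoxy group, would help to tell them apart. On these data alone, it also remains open whether the same capping would have a similar effect with the 3-(trifluoromethyl)phenyl group of compound 2 in place of the 4-fluorophenyl group.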